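Aryl swap on the core of compound 1

This account rests on a few compounds, and the source may have more. Where it says the series, first, only, none or still open, it means among the compounds named here.

Within the data shown here, compound 1 `C=CCn1c(=O)/c(=C\c2cccc(F)c2)[nH]c(=O)/c1=C\c1ccccc1OC` is the only member of the series with a numerical result so far: in a functional assay on K562 cells (Homo sapiens) for cytotoxicity, read by CCK-8 assay, with a stated time of 72 h (a lower number here means a stronger inhibitor, a higher number a weaker inhibitor), compound 1 gives 4100 nM. Compound 2 `C=CCn1c(=O)/c(=C\c2cccc(Br)c2)[nH]c(=O)/c1=C\c1cccc(Br)c1` carries no number; in this assay compound 2 is recorded as "not active" (no number reported), which tells nothing about where it would stand relative to compound 1. Compound 3 `C=CCn1c(=O)/c(=C\c2ccc(C)cc2)[nH]c(=O)/c1=C\c1ccccc1OC` remains to be measured. It differs from compound 1 in one place: 4-methylphenyl in place of 3-fluorophenyl on a double-bonded chain carbon bound to an aromatic carbon. Among the measured compounds shown here, no measured pair of compounds in this set isolates such a change, so there is no observed step to lean on, and the expectation is a step from compound 1 to compound 3 of a 1.3-fold higher number from compound 1 to compound 3 (0.13 log units; within the scatter), not beyond the usual scatter, if anything leaning slightly weaker. For compound 3 the estimate in this assay is 5500 nM, with an expected range from 1500 nM to 20000 nM.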

Compound 3, half-maximal inhibitory concentration: "not active" (no number reported)
Nothing numeric was reported for compound 3, and the estimate cannot be compared.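

In this assay, among these compounds, compound 3 is recorded as "not active" without a number, and no step from compound 1 to compound 3 can be read. Nothing available bears on this result. On these data alone, how far 4-methylphenyl in place of 3-fluorophenyl shifts the number on the shared core remains open.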